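Widening the ester group on a nitrophenyl amide

The source may hold more compounds than are shown below. What is called first, only, known or untested is meant among the compounds shown, and "the series" means these compounds.

Compound 1 `O=C(/C=C/c1ccccc1)OC1(C(=O)Nc2ccc([N+](=O)[O-])cc2)CCCCC1` gives 52.9 nM in a functional assay on HepG2 cells (Homo sapiens) for inhibition, read by MTT assay, with a stated time of 72 h; a higher number here means a weaker inhibitor, a lower number a stronger inhibitor.
Compound 2 `CC(=O)OC1(C(=O)Nc2ccc([N+](=O)[O-])cc2)CCCCC1` gives 519 nM in this assay.

Going by the values given here, compound 2 stands at the highest of the two numbers; the one step measured, a 9.8-fold higher number from compound 1 to compound 2 (0.99 log units; beyond the scatter), separates it from compound 1, which is its nearest neighbour. Compound 3 `O=C(OC1(C(=O)Nc2ccc([N+](=O)[O-])cc2)CCCCC1)C(O)c1ccccc1` differs from compound 2 in one place: hydroxy(phenyl)methyl in place of methyl on a carbonyl carbon. Only a 9.8-fold higher number from compound 1 to compound 2 (0.99 log units; beyond the scatter) bears on this change, and it shows that the ester carrying a six-membered aromatic ring gave the lower number. The group entering in compound 3 also brings such a ring, together with a hydroxy group that compound 1 does not have, so a step of similar direction but uncertain size is expected. Compound 3 is therefore expected at 150 nM, within 40 nM to 600 nM. This expected change, a 3.5-fold lower number from compound 2 to compound 3 (0.54 log units; beyond the scatter), points towards stronger inhibition.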

Compound 3, half-maximal inhibitory concentration: 7.7 nM
The estimate for compound 3 lay 19-fold (1.29 log units) above the measured number; measured number outside the range, below it.
By their numbers in this assay, from the lowest: compound 3; then compound 1; then compound 2.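

The ester position responds far more strongly than the first pair showed: in this assay, hydroxy(phenyl)methyl in place of methyl on the carbonyl carbon gives a 67-fold lower number from compound 2 to compound 3 (1.83 log units; beyond the scatter) and places compound 3 lowest of the three. Both larger groups carry a six-membered aromatic ring, yet hydroxy(phenyl)methyl in place of 2-phenylethenyl still gives a 6.9-fold lower number from compound 1 to compound 3 (0.84 log units; beyond the scatter) in this comparison, so the presence of that ring does not set the number on its own. Nothing measured on these compounds gives a reason for either step.

The compounds shown leave open how much of the drop belongs to the hydroxy group, which a benzyl group at this place would help separate from the ring. From the compounds shown here alone, it also remains open whether an amine or a methoxy group could stand in for that hydroxy group.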